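A Benzyloxy Extension at the Aryl Ketone End

A few compounds are considered here, and "the series" means these few. Any claim that something is new, unique, unknown or untested is made for them only; others in the source may bear on it.

Compound 1, `O=C(/C=C/c1ccc2c(c1)B(O)OC2)c1ccccc1`: in a functional assay on HCT-116 cells (Homo sapiens) for cytotoxicity, read by MTT assay, with a stated time of 48 h (a lower number here means a stronger inhibitor, a higher number a weaker inhibitor), compound 1 gives 6100 nM.
Compound 2, `CCc1ccc(C(=O)/C=C/c2ccc3c(c2)B(O)OC3)cc1`: in this assay compound 2 gives 10900 nM.
Compound 3, `CSc1ccc(C(=O)/C=C/c2ccc3c(c2)B(O)OC3)cc1`: in this assay compound 3 gives 10300 nM.

Of the three numbers, that of compound 1 is the lowest, yet its nearest neighbour, compound 3, and its furthest, compound 2, both lie within the scatter of it, so no ranking among the three can be claimed. Compound 4, `O=C(/C=C/c1ccc2c(c1)B(O)OC2)c1ccc(OCc2ccccc2)cc1`, has not yet been measured. It differs from compound 1 by benzyloxy in place of hydrogen on an aromatic carbon. Among the compounds with values here, two measured steps bear on this change, each placing a group on the same aromatic carbon of the shared core: a 1.8-fold higher number from compound 1 to compound 2 (0.25 log units; within the scatter) and a 1.7-fold higher number from compound 1 to compound 3 (0.23 log units; within the scatter). Both fall within the scatter. Within the data shown here, the benzyloxy group brings more heavy atoms than either ethyl or methylsulfanyl, and nothing among the measured compounds shows how a larger group at that place behaves. The account therefore expects only a modest rise in number, a 1.5-fold higher number from compound 1 to compound 4 (0.17 log units; within the scatter), carried with wide uncertainty. Compound 4 is estimated at 9000 nM, expected to lie between 4000 nM and 20000 nM.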

Compound 4, half-maximal inhibitory concentration: 12100 nM
Estimate against measurement, compound 4: 1.3-fold (0.13 log units) below; the measured number falls inside the stated range.
By their numbers in this assay, from the lowest: compounds 1, 3, 2 and 4 (each within the scatter of the next).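

With benzyloxy, a group of 8 heavy atoms carrying its own six-membered aromatic ring of carbon only, on the aromatic carbon that held ethyl and methylsulfanyl, this assay shows a 2.0-fold higher number from compound 1 to compound 4 (0.30 log units; within the scatter) and this step is still printed as within the scatter, so a far larger group at this place gives no step beyond the scatter. The exchanges among the groups at this place behave alike, with a 1.2-fold higher number from compound 3 to compound 4 (0.07 log units; within the scatter) and a 1.1-fold higher number from compound 2 to compound 4 (0.05 log units; within the scatter) both within the scatter, so ethyl, methylsulfanyl and benzyloxy cannot be told apart by this read-out, and the larger group adds no separation that the two smaller groups had not already failed to give. No evidence is at hand that would explain these numbers.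

What the compounds shown leave open is whether any group on this aromatic carbon can move the number beyond the scatter in either direction, as an amine or a carboxylic acid might or might not. They also leave open whether the oxygen or the second ring of benzyloxy counts for anything, which methoxy or a plain phenyl group at the same place would begin to separate.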